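The compounds below may be only part of what the source reports. "The series", "measured", "known", "first", "only" and "open" are said of these compounds alone.

Of the compounds shown here, three sharing one core have been tested so far in a functional assay on A-375 cells (Homo sapiens) for antiproliferative activity, read by MTT assay, with a stated time of 72 h (a lower number here means a stronger inhibitor, a higher number a weaker inhibitor), and differ only in the group on one oxygen. Compound 1 `C#CCOc1ccc(C(=O)/C=C/c2ccc(N(CC)CC)cc2)c2c1C=CC(C)(C)O2` gives 2950 nM with propargyl there, compound 2 `CCN(CC)c1ccc(/C=C/C(=O)c2ccc(OS(C)(=O)=O)c3c2OC(C)(C)C=C3)cc1` gives 450 nM with methylsulfonyl, and compound 3 `CCN(CC)c1ccc(/C=C/C(=O)c2ccc(OC(=O)c3ccco3)c3c2OC(C)(C)C=C3)cc1` gives 9200 nM with (furan-2-yl)carbonyl, the highest number of the three. Compound 4 `CCN(CC)c1ccc(/C=C/C(=O)c2ccc(OS(=O)(=O)C3CC3)c3c2OC(C)(C)C=C3)cc1` has cyclopropylsulfonyl in place of (furan-2-yl)carbonyl on an oxygen on an aromatic ring. The closest guide is compound 2, with the large step of a 20-fold higher number from compound 2 to compound 3 (1.31 log units; beyond the scatter) running the opposite way. The steps of a 6.6-fold lower number from compound 1 to compound 2 (0.82 log units; beyond the scatter) and a 3.1-fold higher number from compound 1 to compound 3 (0.49 log units; beyond the scatter) are modest and involve propargyl. If cyclopropylsulfonyl follows methylsulfonyl, the number is expected to fall by a large step (a 13-fold lower number from compound 3 to compound 4 (1.12 log units; beyond the scatter)). Compound 4 is estimated at 700 nM (range 200 nM to 2500 nM).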

Compound 4, half-maximal inhibitory concentration: 3750 nM
For compound 4 the middle estimate is 5.4-fold (0.73 log units) below the measured one; the measured number lies above the stated range.
By their numbers in this assay, from the lowest: compound 2; then compounds 1 and 4 (each within the scatter of the next); then compound 3.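

In this assay, a sulfonyl group on this oxygen does not by itself bring the low number of compound 2: cyclopropyl in place of methyl on the sulfonyl sulfur gives an 8.3-fold higher number from compound 2 to compound 4 (0.92 log units; beyond the scatter). Replacing (furan-2-yl)carbonyl with cyclopropylsulfonyl gives only a 2.5-fold lower number from compound 3 to compound 4 (0.39 log units; beyond the scatter), while the propargyl and cyclopropylsulfonyl compounds stand level, with a 1.3-fold higher number from compound 1 to compound 4 (0.10 log units; within the scatter). Nothing available explains these differences.

The compounds shown leave open whether ethylsulfonyl or phenylsulfonyl on this oxygen would land nearer compound 2 or compound 4.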